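The source may report more compounds than this note shows. Statements on the series, on what has been measured and on what is new or still open speak of the compounds shown alone.

compound 1 `NC(=O)c1ccccc1NC(=O)COc1ccccc1`: 8900 nM
compound 2 `NC(=O)c1cc(I)ccc1NC(=O)COc1ccc(Cl)cc1Cl`: 6900 nM

In a functional assay on K562 cells (Homo sapiens) for inhibition, read by trypan blue exclusion, with a stated time of 24 h (on this read-out lower numbers stand for stronger inhibition and higher numbers for weaker inhibition), compound 1 gives 8900 nM and stands within the usual scatter of compound 2, which gives 6900 nM here, so these two values cannot be told apart. The next compound, compound 3 `Cc1ccc(NC(=O)COc2ccccc2)c(C(N)=O)c1`, is compound 1 with one change: methyl in place of hydrogen on an aromatic carbon, in short methyl in place of hydrogen on an aromatic carbon. Going by the values given here, no measured pair isolates a change of this kind, so the data offer no direct guide to its size. Compound 1 at 8900 nM is therefore the anchor: with only a methyl added, no step beyond the scatter is expected in this assay, in either direction. The expected change is a 1.1-fold lower number from compound 1 to compound 3 (0.05 log units; within the scatter), which is an estimate and not a measurement. For compound 3 the estimated value is 8000 nM, with an expected range from 4000 nM to 16000 nM.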

Compound 3, half-maximal inhibitory concentration: 4700 nM
The estimate for compound 3 lay 1.7-fold (0.23 log units) above the measured number, within the range that was stated.
By their numbers in this assay, from the lowest: compounds 3, 2 and 1 (each within the scatter of the next).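

Placing a methyl on this aromatic carbon, meta to a carbamoyl group and para to a large group, gives a 1.9-fold lower number from compound 1 to compound 3 (0.28 log units; within the scatter) in this assay and so leaves the number within the scatter. Going by these compounds alone, this is the only measured pair that isolates a single change, and it shows that this position accepts one added carbon with no step beyond the scatter, in a read-out where the core of compound 1 sits in the same range. Nothing measured here bears on why the number falls where it does.

On these data alone, whether a larger or differently built group at this position, such as an ethyl chain, an amine or a carboxylic acid, would give a step beyond the scatter stays open. So does the effect of the same methyl at other places on this ring.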